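The compounds below may be only part of what the source reports. "The series", "measured", "known", "first", "only" and "open" are said of these compounds alone.

Measured compounds:
Compound 1 `Nc1cc(-c2ccccc2)ccc1NC(=O)c1ccc(CNc2nccc(-c3cccnc3)n2)cc1` gives > 20000 nM in an assay for inhibition of histone deacetylase 8 (Homo sapiens), read by fluorescence, with stated times of 15 min and 60 min; on this read-out higher numbers stand for weaker inhibition and lower numbers for stronger inhibition; this value is a limit of the assay, not a number.
Compound 2 `Nc1ccccc1NC(=O)c1ccc(CNC2=NC(=O)C(Cc3ccccc3)N2)cc1` gives 13000 nM in this assay.

Compound 1 therefore stands at the weak end of what this assay reports, sitting at the limit of > 20000 nM in this assay, at which 1 of the 2 values shown sits. Compound 3 `Nc1cc(C(=O)O)ccc1NC(=O)c1ccc(CNc2nccc(-c3cccnc3)n2)cc1` differs from compound 1 by carboxy in place of phenyl on an aromatic carbon. Among the compounds with values here, no step between measured compounds is at hand to guide the expectation. Compound 3 is expected to stay about where compound 1 stands, with a step that the limit leaves unreadable from compound 1 to compound 3 that probably lies within the scatter, and likely again only a limit will be reported. Compound 3 is estimated at 25000 nM, between 8000 nM and 80000 nM.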

Compound 3, half-maximal inhibitory concentration: > 20000 nM
Compound 3 ended at the assay's limit; the forecaster's own chance of this, stated with the estimate: 60%; the middle value is on the limit's open side.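

Compound 1 and compound 3 both sit at a limit of this assay, not at a number, and the step between them cannot be read. Going by these compounds, whether carboxy in place of phenyl changes inhibition at all remains open.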